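This account rests on a few compounds, and the source may have more. Where it says the series, first, only, none or still open, it means among the compounds named here.

In an ADME assay on Huh-7 cells (Homo sapiens) for cytotoxicity, read by XTT assay (on this read-out lower numbers stand for higher toxicity in this test and higher numbers for lower toxicity in this test), compound 2 `OCC(CO)CCn1cnc2c(Cl)ncnc21` stands at > 200000 nM, which is a limit of the assay and not a number. Compound 3 `O=C(OCC(CO)CCn1cnc2c(Cl)ncnc21)c1ccccc1` differs from it by one change: benzoyl in place of hydrogen on an oxygen on a saturated carbon. Compound 1 `O=C(OC[C@@H]1C[C@@H](O)[C@H](n2cnc3c(Cl)ncnc32)O1)c1ccccc1`, which also carries a benzoyl, gives 70500 nM, so a moderate move toward lower numbers, meaning higher toxicity in this assay, is expected. The expected change is an at least 1.8-fold lower number from compound 2 to compound 3 (0.25 log units; that floor lies within the scatter). For compound 3 the estimated value is 110000 nM, within an expected range of 50000 nM to 200000 nM.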

Compound 3, half-maximal cytotoxic concentration: 108000 nM
The estimate for compound 3 lay 1.0-fold (0.01 log units) above the measured number, and the stated range covers the measured number.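

With benzoyl in place of hydrogen on an oxygen on a saturated carbon, this assay shows an at least 1.8-fold lower number from compound 2 to compound 3 (0.26 log units; that floor lies within the scatter). Compound 3 thus shows that a compound with this benzoyl on this oxygen gives a number inside the range of the test. The value of compound 2 is a limit and not a number, so only a floor of the step can be read: the limit of > 200000 nM in this assay, at which 1 of the 3 values shown sits.

The compounds shown leave open whether this reading is specific to benzoyl. An acetyl or a longer carbon chain on the same oxygen could give a different number.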